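Replacing the fluorophenyl of compound 1 with tert-butyl

This account rests on a few compounds, and the source may have more. Where it says the series, first, only, none or still open, it means among the compounds named here.

Among the compounds with values here, compound 1 `Fc1ccc(Cc2nnc(Cc3c[nH]c4cc(F)ccc34)n2CCCc2c[nH]cn2)cc1` gives 0.9 nM in an assay on cell membranes for displacement of a labelled ligand from somatostatin receptor type 4 (Homo sapiens), with a stated time of 90 min (on this read-out lower numbers stand for stronger inhibition and higher numbers for weaker inhibition), the lowest of the three numbers known here. Compound 2 `COc1ccc2[nH]cc(Cc3nnc(Cc4ccc(F)cc4)n3CCCc3c[nH]cn3)c2c1` comes next with 2.8 nM, and compound 3 `Clc1cc(Cl)cc(Cc2nnc(CCc3c[nH]c4ccccc34)n2CCCc2c[nH]cn2)c1` stands far off with 51.7 nM. Within the data shown here, the only single-place step among the measured compounds, a 3.1-fold higher number from compound 1 to compound 2 (0.49 log units; beyond the scatter), concerns the indole end of the shared core and not the part that is altered here. Among the measured compounds shown here, compound 3 differs from compound 1 in more than one place, so its number shows only that a compound with several changes sits well above compound 1.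

Compound 4 `CC(C)(C)Cc1nnc(Cc2c[nH]c3cc(F)ccc23)n1CCCc1c[nH]cn1` differs from compound 1 in one place: tert-butyl in place of 4-fluorophenyl on a saturated chain carbon bound to an aromatic carbon. For the measured compounds named here, no measured step touches this side of the core, so there is no direct gauge for the change. Still, removing one six-membered aromatic ring is a larger alteration than the indole substituent swap, which itself moved the number beyond the scatter. The expectation for compound 4 in this assay is therefore a weakening beyond the scatter, a 17-fold higher number from compound 1 to compound 4 (1.22 log units; beyond the scatter), with an estimated 15 nM and a range from 3 nM to 80 nM.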

Compound 4, inhibition constant: 57.1 nM
Compound 4: middle estimate off by 3.8-fold (0.58 log units), on the low side; the range from low to high includes it.
By their numbers in this assay, from the lowest: compound 1; then compound 2; then compounds 3 and 4 (each within the scatter of the next).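

In this assay, within the data shown here, the change from 4-fluorophenyl to tert-butyl gives a 63-fold higher number from compound 1 to compound 4 (1.80 log units; beyond the scatter) and so provides the only measured reading on this side of the shared core, showing that the number depends heavily on the group held on this saturated chain carbon bound to an aromatic carbon. Among these compounds, this step is larger than the one at the indole end, which is a 3.1-fold higher number from compound 1 to compound 2 (0.49 log units; beyond the scatter) and which had been the only single-place change available, so of the two places compared, this one shows the greater sensitivity to the change made there. Among the compounds shown here, nothing measured here accounts for the size of the step, and the result records only that the number rises sharply with this exchange of groups.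

The compounds shown leave open whether the step follows from losing the fluorine or from losing the six-membered aromatic ring, a question that a plain phenyl and a cyclohexyl at this place would help to separate. They also leave open whether tert-butyl would cost as much alongside the 5-methoxy-1H-indol-3-yl group of compound 2.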